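Losing one acyl group from compound 3

The compounds below may be only part of what the source reports. "The series", "measured", "known", "first", "only" and "open" are said of these compounds alone.

Compound 1 `CC(C)=CC(=O)NC(=N)N`: > 100000 nM, a limit of the assay
Compound 2 `CC(C)=CC(=O)NC(=N)NC(=O)C=C(C)C`: 75600 nM
Compound 3 `CC(C)=CCC/C(C)=C/C(=O)NC(=N)NC(=O)C=C(C)C`: 37400 nM

In a functional assay on A549 cells (Homo sapiens) for inhibition, read by MTT assay, with a stated time of 72 h (a higher number here means a weaker inhibitor of growth, a lower number a stronger inhibitor of growth), compound 3 holds the lowest number of the two true values, and compound 2 is its nearest neighbour, a 2.0-fold lower number from compound 2 to compound 3 (0.31 log units; beyond the scatter). Compound 4 `CC(C)=CCC/C(C)=C/C(=O)NC(=N)N` differs from compound 3 by one change, hydrogen in place of (2-methylprop-1-en-1-yl)carbonyl on an amine nitrogen. The same loss separates compound 2 from compound 1, but compound 1 has only a limit, so this pair suggests a direction and no size. Compound 4 keeps the 3-methylbut-2-en-1-yl of the modest measured step. A weaker result in this assay is expected, with an estimated 1.7-fold higher number from compound 3 to compound 4 (0.24 log units; within the scatter). Compound 4 is estimated at 65000 nM, with an expected range of 32000 nM to 100000 nM.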

Compound 4, concentration for 50% growth inhibition: 76500 nM
Estimate against measurement, compound 4: 1.2-fold (0.07 log units) below, and the stated range covers the measured number.
By their numbers in this assay, from the lowest: compound 3; then compounds 2 and 4 (each within the scatter of the next). At a limit, above all of these: compound 1.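

The loss of the (2-methylprop-1-en-1-yl)carbonyl from the amine nitrogen now has a measured size in this assay, beyond a mere direction (a 2.0-fold higher number from compound 3 to compound 4 (0.31 log units; beyond the scatter)). The 3-methylbut-2-en-1-yl also points the same way on a second core (an at least 1.3-fold lower number from compound 1 to compound 4 (0.11 log units; that floor lies within the scatter)). Compound 1 stands at a limit, so the two gains cannot be compared: the same change on two cores in this assay, a 2.0-fold lower number (0.31 log units; beyond the scatter) from compound 2 to compound 3 and an at least 1.3-fold lower number (0.11 log units; that floor lies within the scatter) from compound 1 to compound 4; the limit leaves it open whether they differ.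

As far as these compounds go, whether an acyl group with a longer chain on that nitrogen would lower the number further stays open, as does the effect of a carboxylic acid or an amine at the end of the chain.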